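A few compounds are considered here, and "the series" means these few. Any claim that something is new, unique, unknown or untested is made for them only; others in the source may bear on it.

Compound 3 `c1ccc2c(c1)CCN(c1ccnc(Nc3ccc(Oc4ncnc5sccc45)cc3)n1)C2` stands lowest of the three compounds measured in a functional assay on A549 cells (Homo sapiens) for inhibition, read by MTT assay, with a stated time of 72 h, tested at 20 uM (on this read-out lower numbers stand for less inhibition and higher numbers for more inhibition at the one concentration tested (going by the name of the read-out)), where compound 3 gives 34%. Compound 2 `c1ccc2c(c1)CCN(c1ccnc(Nc3ccc(Oc4ncnc5ccsc45)cc3)n1)C2` gives 54.9%, and compound 1 `CNC(=O)c1cc(Oc2ccc(Nc3nccc(N4CCCC4)n3)cc2)ccn1` gives 59.6%. Among the measured compounds shown here, the one measured step between compounds that differ in a single place is a number 20.9 percentage points lower from compound 2 to compound 3 (beyond the scatter), a swap of one group of nine heavy atoms for another on the ether oxygen.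

Compound 4 `CNC(=O)c1cc(Oc2ccc(Nc3nccc(N4CCc5ccccc5C4)n3)cc2)ccn1` differs from compound 3 in that (a group of 10 heavy atoms (7 carbon, 2 nitrogen, 1 oxygen; one six-membered aromatic ring with 1 hetero atom) in place of a group of 9 heavy atoms (6 carbon, 2 nitrogen, 1 sulfur; one five-membered aromatic ring with 1 hetero atom, one six-membered aromatic ring with 2 hetero atoms), on an oxygen on an aromatic ring). For the measured compounds named here, no measured step covers this change directly; compound 1 carries the same entering group and gives 59.6%, while the remainder of the structure of compound 4 is shared by compound 2, which gives 54.9%. Because compound 1 gives 59.6%, compound 4 is expected to give about 55%, within 35% to 75%. That would be an expected rise of a number 21 percentage points higher from compound 3 to compound 4 (beyond the scatter), beyond the scatter.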

Compound 4, a percentage reported as inhibition, at one concentration (the size of the read-out at that concentration, not a potency): 59.6%
For compound 4 the middle estimate is 4.6 percentage points below the measured one; the measured number falls inside the stated range.
By their numbers in this assay, from the lowest: compound 3; then compounds 2, 1 and 4 (each within the scatter of the next).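

In this assay, 2-(methylcarbamoyl)pyridin-4-yl on the oxygen reads clearly better than the group of compound 3 (a number 25.6 percentage points higher from compound 3 to compound 4 (beyond the scatter)), but it cannot be told apart from the group of compound 2 (a number 4.7 percentage points higher from compound 2 to compound 4 (within the scatter)). On the aromatic carbon, 1,2,3,4-tetrahydroisoquinolin-2-yl in place of pyrrolidin-1-yl leaves the reading unchanged (no change at the digits printed from compound 1 to compound 4 (within the scatter)). Nothing measured here explains these readings. As far as these compounds go, it remains open whether a morpholin-4-yl group on that carbon would hold the reading, and whether a carboxylic acid in place of the methyl amide would do so on the pyridine.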